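Triazole substituent variation on the shared core: compound 4

This account rests on a few compounds, and the source may have more. Where it says the series, first, only, none or still open, it means among the compounds named here.

Measured so far:
- compound 1, `COc1ccccc1-c1cn(C[C@H](O)[C@H]2OC(=O)C(OCc3ccccc3)=C2OCc2ccccc2)nn1`: in a functional assay on HCT-116 cells (Homo sapiens) for antiproliferative activity, read by MTT assay, with a stated time of 72 h (a higher number here means a weaker inhibitor, a lower number a stronger inhibitor), compound 1 gives only a limit, > 100000 nM.
- compound 2, `O=C1O[C@H]([C@@H](O)Cn2cc(C3CC3)nn2)C(OCc2ccccc2)=C1OCc1ccccc1`: in this assay compound 2 gives 30400 nM.
- compound 3, `O=C1O[C@H]([C@@H](O)Cn2cc(CNS(=O)(=O)c3ccc(Cl)cc3)nn2)C(OCc2ccccc2)=C1OCc1ccccc1`: in this assay compound 3 gives 8380 nM.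

Compound 3 holds the lowest of the two numbers shown; its nearest neighbour is compound 2, separated by a 3.6-fold lower number from compound 2 to compound 3 (0.56 log units; beyond the scatter). Compound 1 sits at the limit of > 100000 nM in this assay, at which 1 of the 3 values shown sits, so its distance from compound 3 is known only as a bound, an at least 11-fold lower number from compound 1 to compound 3 (1.07 log units; beyond the scatter).

Compound 4, `O=C1O[C@H]([C@@H](O)Cn2cc(-c3cc(F)cc(F)c3)nn2)C(OCc2ccccc2)=C1OCc1ccccc1`, differs from compound 3 in one place: 3,5-difluorophenyl in place of (((4-chlorophenyl)sulfonyl)amino)methyl on an aromatic carbon. Among the measured compounds shown here, the steps that bear on this change are those that move an aromatic six-membered substituent in or out of the same position on the triazole. Going from compound 1 to compound 3 gave an at least 11-fold lower number from compound 1 to compound 3 (1.07 log units; beyond the scatter), and from compound 1 to compound 2 gave an at least 3.2-fold lower number from compound 1 to compound 2 (0.51 log units; beyond the scatter); both show the aryl-bearing compound 1 as the weaker one, with no number below the limit. Returning an aryl group in compound 4 is therefore expected to raise the number again, and the step of a 7.2-fold higher number from compound 3 to compound 4 (0.85 log units; beyond the scatter) is expected to be large rather than within the scatter. For compound 4 the estimate in this assay is 60000 nM, with a range from 15000 nM to 150000 nM, and a fair chance that only a limit is returned.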

Compound 4, half-maximal inhibitory concentration: 48200 nM
Compound 4: middle estimate off by 1.2-fold (0.10 log units), on the high side; measured number inside the range.
By their numbers in this assay, from the lowest: compound 3; then compounds 2 and 4 (each within the scatter of the next). At a limit, above all of these: compound 1.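

Two aryl groups at this aromatic carbon of the five-membered ring now read apart in this assay: 3,5-difluorophenyl in place of 2-methoxyphenyl gives an at least 2.0-fold lower number from compound 1 to compound 4 (0.31 log units; beyond the scatter). Among the compounds shown here, compound 1 gives only a limit, so that step is a bound and not a measured distance: the limit of > 100000 nM in this assay, at which 1 of the 4 values shown sits. For the first time, an aryl group can be set against cyclopropyl as a number rather than a bound, and a 1.6-fold higher number from compound 2 to compound 4 (0.20 log units; within the scatter) leaves these two substituents indistinguishable here, while a 5.8-fold higher number from compound 3 to compound 4 (0.76 log units; beyond the scatter) shows that replacing the (((4-chlorophenyl)sulfonyl)amino)methyl group with this aryl group loses the advantage held by compound 3.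

Compound 3 alone carries the sulfonyl, the amino hydrogen and the methylene link in one substituent, so the compounds shown do not assign its lower number to any one of these parts or to its chlorine. Also open, on these data alone, is how a simple aminomethyl group, a carboxylic acid or a longer chain at this aromatic carbon would read in this assay, and whether any such group would reach a lower number than compound 3 gives.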